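Swapping the aryl ether: from compound 3 to compound 4

The source may report more compounds than this note shows. Statements on the series, on what has been measured and on what is new or still open speak of the compounds shown alone.

Measured so far:
compound 1, `CC(C)Oc1ccc(C(C)(C)O)cc1-c1cn(C)c(=O)c2[nH]c(C(=O)NCc3ccc(C(=O)NO)cc3)cc12`: 350 nM
compound 2, `Cn1cc(-c2cc(C(C)(C)O)ccc2Oc2ccc(F)cc2F)c2cc(C(=O)NCCCCCCC(=O)NO)[nH]c2c1=O`: 250 nM
compound 3, `Cc1cc(F)cc(C)c1Oc1ccc(C(C)(C)O)cc1-c1cn(C)c(=O)c2[nH]c(C(=O)NCc3ccc(C(=O)NO)cc3)cc12`: 440 nM

In a functional assay on MV4-11 cells (Homo sapiens) for antiproliferative activity, read by CCK-8 assay, with a stated time of 72 h (on this read-out lower numbers stand for stronger inhibition and higher numbers for weaker inhibition), compound 3 gives 440 nM. The three numbers sit close together, and compound 3 cannot be separated from compound 1 or compound 2 on this read-out. Among the compounds with values here, the one step that touches the aryl ether position is a 1.3-fold higher number from compound 1 to compound 3 (0.10 log units; within the scatter), a change that stays inside the scatter. Compound 2, which carries the 2,4-difluorophenoxy group but a different chain to the hydroxamic acid, gives 250 nM, again close to compound 3.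

Compound 4, `Cn1cc(-c2cc(C(C)(C)O)ccc2Oc2ccc(F)cc2F)c2cc(C(=O)NCc3ccc(C(=O)NO)cc3)[nH]c2c1=O`, keeps the benzyl hydroxamate of compound 3 and changes the ether: 2,4-difluorophenyl in place of 4-fluoro-2,6-dimethylphenyl on an oxygen on an aromatic ring. Within the data shown here, the only comparable step, from compound 1 to compound 3, was within the scatter, and compound 2 shows that the 2,4-difluorophenoxy group sits with the others in this narrow band. The expected step is therefore a 1.3-fold lower number from compound 3 to compound 4 (0.10 log units; within the scatter), none beyond the scatter. Compound 4 is estimated at 350 nM in this assay, with a range of 150 nM to 800 nM.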

Compound 4, half-maximal inhibitory concentration: 190 nM
Compound 4: middle estimate off by 1.8-fold (0.27 log units), on the high side, and the stated range covers the measured number.
By their numbers in this assay, from the lowest: compounds 4, 2, 1 and 3 (each within the scatter of the next, the first and the last beyond it).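

In this assay, the ether position gives its first step beyond the scatter (a 2.3-fold lower number from compound 3 to compound 4 (0.36 log units; beyond the scatter)), a modest one, so the two aryl groups on this oxygen can be told apart on this read-out. Neither can be told apart from isopropyl, since the step to the 2,4-difluorophenyl ether stays within the scatter (a 1.8-fold lower number from compound 1 to compound 4 (0.27 log units; within the scatter)), and with the 2,4-difluorophenoxy group held fixed, 4-(hydroxycarbamoyl)phenyl and 5-(hydroxycarbamoyl)pentyl also cannot be separated (a 1.3-fold lower number from compound 2 to compound 4 (0.12 log units; within the scatter)). Nothing among the data shown accounts for the step at the ether position.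

The exchange from 4-fluoro-2,6-dimethylphenyl to 2,4-difluorophenyl alters more than one substituent at once, so the compounds shown leave open which of these alterations carries the step, a question that a plain phenyl, a 4-fluorophenyl or a 2,6-dimethylphenyl on the same oxygen would address. They also leave open whether the step holds with the 5-(hydroxycarbamoyl)pentyl chain in place of the benzyl hydroxamate, and how a basic amine on the aryl ether would compare.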